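A few compounds are considered here, and "the series" means these few. Any claim that something is new, unique, unknown or untested is made for them only; others in the source may bear on it.

Measured compounds:
compound 1 `FC(F)(F)c1ccc(N2CCN(c3ncnc4[nH]cnc34)CC2)cc1` — 5100 nM
compound 2 `FC(F)(F)c1cccc(CNc2ncnc3[nH]cnc23)c1` — 102000 nM
compound 3 `Cc1ccc(S(=O)(=O)n2cnc3c(NCCC4C=CCCC4)ncnc32)cc1` — 8700 nM

All three were tested in a functional assay on HCT-116 cells (Homo sapiens) for cytotoxicity, read by sulforhodamine B assay, with a stated time of 72 h; a higher number here means a weaker inhibitor, a lower number a stronger inhibitor. Compound 1, with the structure `FC(F)(F)c1ccc(N2CCN(c3ncnc4[nH]cnc34)CC2)cc1`, gives the lowest of the three numbers. The nearest to it is compound 3, whose value in this assay lies within the usual scatter of compound 1, so the two cannot be told apart. Compound 2 stands much further away, and its gap to compound 1 goes well beyond that scatter.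

The next compound, compound 4 `CCOC(=O)Cn1cnc2c(N3CCN(c4ccc(C(F)(F)F)cc4)CC3)ncnc21`, keeps the whole of compound 1 and changes a single spot: (ethoxycarbonyl)methyl in place of hydrogen on an aromatic nitrogen. Among the measured compounds shown here, nothing among the measured compounds shows this exact exchange on an otherwise identical structure, so there is no directly comparable step to lean on. Compound 3 does carry a substituent on the same ring nitrogen, but with a different group there and a different group elsewhere, so its value only shows that such a substitution is compatible with a number of the same order as compound 1.

On that basis, the expected step from compound 1 to compound 4 in this assay is a 1.3-fold higher number from compound 1 to compound 4 (0.11 log units; within the scatter), most likely not beyond the scatter. Compound 4 is therefore estimated at 6500 nM, within a range of 2000 nM to 22000 nM.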

Compound 4, half-maximal inhibitory concentration: 72400 nM
For compound 4 the middle estimate is 11-fold (1.05 log units) below the measured one; measured number above the stated range.
By their numbers in this assay, from the lowest: compounds 1 and 3 (each within the scatter of the next); then compounds 4 and 2 (each within the scatter of the next).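

In this assay, (ethoxycarbonyl)methyl in place of hydrogen on the aromatic nitrogen gives a 14-fold higher number from compound 1 to compound 4 (1.15 log units; beyond the scatter), a large step well beyond the scatter. Among the compounds shown here, this is the first change here that can be read on an otherwise identical structure, and it shows that this ring nitrogen is not a neutral spot: what sits there can strongly shift the number for the compound as a whole. No measurement of any other property of these two compounds is at hand to explain the rise.

As far as these compounds go, this one step cannot separate the effect of losing the hydrogen on the ring nitrogen from the effect of the particular group that enters, so it remains open whether every substituent there costs this much. A plain methyl, a free carboxylic acid or a primary amide on the same nitrogen of compound 1 would help to settle this, by showing whether the size of the step follows the ester, the chain or simply the presence of any group at all.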